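The source may report more compounds than this note shows. Statements on the series, on what has been measured and on what is new or still open speak of the compounds shown alone.

Compound 1, `Nc1n[nH]c2cc(-c3ccc(=O)n(Cc4cccc(Cl)c4)c3)ccc12`: 6 nM
Compound 2, `Cn1ncc2ccc(-c3ccc(=O)n(Cc4ccccc4)c3)cc21`: > 2000 nM
Compound 3, `O=C(N1CCOCC1)n1cc(-c2ccc3cn[nH]c3c2)ccc1=O`: > 2000 nM

In an assay for inhibition of MAP kinase-interacting serine/threonine-protein kinase 2 (Homo sapiens), read by luminescence and ADP-Glo, with a stated time of 2 h (a lower number here means a stronger inhibitor, a higher number a weaker inhibitor), compound 3 gives > 2000 nM, which is a limit of the assay and not a number. Compound 2 likewise gives only a limit, > 2000 nM. Compound 1 gives 6 nM, so compound 3 sits among the two weaker entries, at the limit of > 2000 nM in this assay, at which 2 of the 3 values shown sit.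

Compound 4, `O=c1ccc(-c2ccc3cn[nH]c3c2)cn1Cc1ccccc1F`, differs from compound 3 by one change: 2-fluorobenzyl in place of (morpholin-4-yl)carbonyl on an aromatic nitrogen. Compound 1, which carries a halogen-bearing benzyl group on the same kind of aromatic nitrogen, gives 6 nM, a real number rather than a limit.

A step toward stronger inhibition, well beyond the scatter, is therefore expected from compound 3 to compound 4, an at least 20-fold lower number from compound 3 to compound 4 (1.30 log units; beyond the scatter). Compound 4 is estimated at 100 nM, within 10 nM to 1000 nM.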

Compound 4, half-maximal inhibitory concentration: 37 nM
Beside the measured number, compound 4's estimate is 2.7-fold (0.43 log units) above it, and the stated range covers the measured number.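

Compound 3 gives only a limit of the assay, not a number: the limit of > 2000 nM in this assay, at which 2 of the 4 values shown sit.

In this assay, 2-fluorobenzyl in place of (morpholin-4-yl)carbonyl on the aromatic nitrogen gives an at least 54-fold lower number from compound 3 to compound 4 (1.73 log units; beyond the scatter), which shows that the group at this one position can separate a compound with a measurable number from one without. The step is measured from a limit, so its true size could be larger.

Among the compounds shown, no pair isolates the contribution of the fluorine. From the compounds shown here alone, how a phenylethyl chain or a benzyl carrying a carboxylic acid would behave at this nitrogen also stays open.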